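A sulfonamide swap starting from the assay limit

The source may report more compounds than this note shows. Statements on the series, on what has been measured and on what is new or still open speak of the compounds shown alone.

In a functional assay on MIA PaCa-2 cells (Homo sapiens) for inhibition, read by MTT assay, with a stated time of 3 days (a higher number here means a weaker inhibitor, a lower number a stronger inhibitor), compound 1 `CC(C)c1noc(N2CCN(C(=O)[C@@H]3CCCN(S(=O)(=O)c4ccc(S(=O)(=O)NC5CC5)cc4)C3)CC2)n1` gives > 10000 nM as a limit of the assay, not a number. Compound 2 `CC(C)c1noc(N2CCN(C(=O)[C@@H]3CCCN(S(=O)(=O)c4ccc(S(=O)(=O)NC(C)(C)C)cc4)C3)CC2)n1` gives > 10000 nM as a limit too, not a number. Where compound 2 stands is therefore the limit of > 10000 nM in this assay, at which 2 of the 2 values shown sit, and no more. Compound 3 `CCN(CC)S(=O)(=O)c1ccc(S(=O)(=O)N2CCC[C@@H](C(=O)N3CCN(c4nc(C(C)C)no4)CC3)C2)cc1` carries diethylamino in place of (tert-butyl)amino on a sulfonyl sulfur and otherwise matches compound 2. Going by the values given here, the one measured step that bears on this change, also made on a sulfonamide nitrogen, is a step that the two limits leave unreadable from compound 1 to compound 2 and so offers no size to carry over. In this assay the expected move is therefore a step that the limit leaves unreadable from compound 2 to compound 3 and nothing beyond the scatter, in either direction. For compound 3 the estimated value is 12000 nM with an expected range of 5000 nM to 30000 nM in this test.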

Compound 3, half-maximal inhibitory concentration: > 10000 nM
Compound 3: only a limit was reported; the forecaster's own chance of this, stated with the estimate: 80%; the middle value is on the limit's open side.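

Going by these compounds alone, compound 3 also gives a limit of the assay rather than a number, so no step from compound 1 or compound 2 to compound 3 can be read: the limit of > 10000 nM in this assay, at which 3 of the 3 values shown sit.

The compounds shown leave open how any of the three actually ranks in this assay, and whether these sulfonamide changes affect inhibition at all.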